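The source may report more compounds than this note shows. Statements on the series, on what has been measured and on what is new or still open speak of the compounds shown alone.

Compound 1 `O=C1C(=O)N(Cc2ccc(-c3ccncc3)cn2)c2ccc(OC(F)(F)F)cc21`: "not determined" (no result reported)
Compound 2 `O=C1C(=O)N(Cc2ccc(-c3ccccc3)cc2F)c2ccc(OC(F)(F)F)cc21`: 63%
Compound 3 `O=C1C(=O)N(Cc2ccc(-c3cccnc3)cn2)c2ccc(OC(F)(F)F)cc21`: "not determined" (no result reported)

In a functional assay on CHO cells for positive allosteric modulation of muscarinic acetylcholine receptor M5 (Homo sapiens), read by FLIPR and calcium flux, with a stated time of 1 h (a lower number here means a smaller maximal response, a higher number a larger maximal response), compound 2 gives 63%. For the measured compounds named here, this is the only number available: for compound 1 and compound 3 no result was reported, so compound 2 stands alone and cannot be set in order against them. Compound 4 `O=C1C(=O)N(Cc2ccc(-c3ccccc3)cc2)c2ccc(OC(F)(F)F)cc21` has not yet been measured in this assay. It differs from compound 2 in one place: hydrogen in place of fluoro on an aromatic carbon. The fluoro leaves and a hydrogen enters. Going by the values given here, no step between two measured compounds exists against which this change could be sized. The step of a number 3 percentage points lower from compound 2 to compound 4 (within the scatter) is expected to lie within the usual scatter of repeated measurements, with no clear direction. For compound 4 the estimate in this assay is 60%, with a range from 40% to 80%.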

Compound 4, largest response reached (Emax), in percent of the reference or control that the assay uses: < 60%
Compound 4: a limit, no number (the forecaster's own chance of this, stated with the estimate: 0%); the middle value lies on the limit itself.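

Compound 4 carries a limit of the assay and not a number: the limit of < 60% in this assay, at which 1 of the 4 values shown sits.

In this assay, for the compounds shown here, hydrogen in place of fluoro on this aromatic carbon, ortho to a large group, gives a number at least 3 percentage points lower from compound 2 to compound 4 (that floor lies within the scatter), the first step that can be read at this position. The change does not raise the largest response, but this floor does not fix how far it lowers it.

As far as these compounds go, whether the full drop lies beyond the usual scatter stays open. So does what a chlorine atom or a methoxy group on this aromatic carbon would do to the response.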